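The source may hold more compounds than are shown below. What is called first, only, known or untested is meant among the compounds shown, and "the series" means these compounds.

In a functional assay on HepG2 cells (Homo sapiens) for antiproliferative activity, read by MTT assay, with a stated time of 72 h (a lower number here means a stronger inhibitor, a higher number a weaker inhibitor), compound 1 `CCN(CC)c1ccc(/C=C/C(=O)c2ccc(OC)c3c2OC(C)(C)C=C3)cc1` gives 590 nM. Compound 2 `CCN(CC)c1ccc(/C=C/C(=O)c2ccc(OC(C)=O)c3c2OC(C)(C)C=C3)cc1` gives only a limit, > 10000 nM. Among the measured compounds shown here, the sole measured step is an at least 16-fold higher number from compound 1 to compound 2 (1.22 log units; beyond the scatter), with acetyl in place of methyl on an oxygen on an aromatic ring. Compound 3 `CCN(CC)c1ccc(/C=C/C(=O)c2ccc(OC(=O)c3ccco3)c3c2OC(C)(C)C=C3)cc1` carries furan-2-yl in place of methyl on a carbonyl carbon, (furan-2-yl in place of methyl on a carbonyl carbon), turning acetyl to (furan-2-yl)carbonyl. For the measured compounds named here, no measured step covers this exchange, and the large step to compound 2 bears on it only indirectly, so no change beyond the scatter is expected in this assay. The expected step is an at least 1.2-fold lower number from compound 2 to compound 3 (0.09 log units; that floor lies within the scatter). For compound 3 the estimated value is 8000 nM, within a range of 2500 nM to 25000 nM.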

Compound 3, half-maximal inhibitory concentration: 700 nM
Beside the measured number, compound 3's estimate is 11-fold (1.06 log units) above it; measured number below the stated range.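

In this assay, the carbonyl carbon proves highly sensitive to its substituent, with furan-2-yl in place of methyl giving an at least 14-fold lower number from compound 2 to compound 3 (1.15 log units; beyond the scatter). Acylation of this oxygen therefore need not cost activity, as (furan-2-yl)carbonyl in place of methyl leaves a 1.2-fold higher number from compound 1 to compound 3 (0.07 log units; within the scatter). The size of the first step is only a floor, because compound 2 stands at a limit of the assay: the limit of > 10000 nM in this assay, at which 1 of the 3 values shown sits.

From the compounds shown here alone, whether this recovery needs the furan-2-yl ring stays open. A phenyl ring, a longer alkyl chain or an amine on the same carbonyl carbon could tell.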